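Hydroxy to carboxy swap in an amide series, antiproliferative read-out

This account rests on a few compounds, and the source may have more. Where it says the series, first, only, none or still open, it means among the compounds named here.

Measured so far:
compound 1 `Cc1ccc2nc(C(=O)Nc3c(F)cc(-c4cccc(F)c4)cc3F)c(C)c(O)c2c1` gives 1.52% in a functional assay on Hep 3B2 cells (Homo sapiens) for antiproliferative activity, read by MTT assay, with a stated time of 24 h, tested at 0.05 ug/mL; a higher number here means a stronger effect of the compound at the concentration tested, a lower number a weaker effect
compound 2 `COc1ccc2nc(C(=O)Nc3ccc(-c4ccccc4)cc3)c(C)c(O)c2c1` gives 1.23% in this assay
compound 3 `Cc1ccc2nc(C(=O)Nc3c(F)cc(-c4cccc(F)c4)cc3F)c(C)c(C(=O)O)c2c1` gives 2.11% in this assay

All three numbers sit within the scatter of one another; none can be called stronger or weaker. Compound 1 and compound 3 differ by one change, (carboxy in place of hydroxy on an aromatic carbon), and the step is a number 0.6 percentage points higher from compound 1 to compound 3 (within the scatter). Compound 2 shares an amide link with compound 1, but the difference between the two cores is not broken down here.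

Compound 4 `COc1ccc2nc(C(=O)Nc3ccc(-c4ccccc4)cc3)c(C)c(C(=O)O)c2c1` is the unmeasured partner of compound 2, carrying (carboxy in place of hydroxy on an aromatic carbon). The surroundings of the change are described in the same words as for compound 1 to compound 3, so it is the same change on a different core. The step is expected to be a number 0.6 percentage points higher from compound 2 to compound 4 (within the scatter), resting on the earlier a number 0.6 percentage points higher from compound 1 to compound 3 (within the scatter), which stayed within the scatter. For compound 4 the estimate is 1.8%, expected to fall between -4% and 9%.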

Compound 4, a percentage reported as inhibition, at one concentration (the size of the read-out at that concentration, not a potency): 0.65%
Compound 4: middle estimate off by 1.2 percentage points, on the high side; the measured number falls inside the stated range.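

In this assay, carboxy in place of hydroxy on an aromatic carbon results in a number 0.6 percentage points lower from compound 2 to compound 4 (within the scatter). Set side by side, the steps on the two cores do not differ: the same change on two cores in this assay, a number 0.6 percentage points higher (within the scatter) from compound 1 to compound 3 and a number 0.6 percentage points lower (within the scatter) from compound 2 to compound 4, 1.2 percentage points apart, within the scatter of two such steps. This shows that on these two cores the change stays within the scatter at this single concentration, but it does not show that hydroxy and carboxy are interchangeable, nor that the same would hold for a compound with a larger read-out.

The compounds shown leave open whether an amine or an ester at the same place would move the read-out beyond the scatter. They also leave open whether hydroxy and carboxy would separate at a higher concentration.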